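A Methyl Step on the Pendant Phenyl Ring

The source may report more compounds than this note shows. Statements on the series, on what has been measured and on what is new or still open speak of the compounds shown alone.

Compound 2 `COc1cc2c(Oc3ccc(NC(=O)c4nccc(-c5ccccc5)n4)cc3F)ccnc2cc1OCCCN1CCCC1` gives 1360 nM in a functional assay on MKN-45 cells (Homo sapiens) for cytotoxicity, read by MTT assay, with a stated time of 72 h (a higher number here means a weaker inhibitor, a lower number a stronger inhibitor), the higher of the two numbers recorded so far. Compound 1 `COc1cc2c(Oc3ccc(NC(=O)c4nccc(-c5ccc(C)cc5)n4)cc3F)ccnc2cc1OCCCN1CCCCC1` gives 580 nM in this assay. These two compounds differ in two places at once, so the gap between them cannot be assigned to either change on its own. Compound 3 `COc1cc2c(Oc3ccc(NC(=O)c4nccc(-c5ccc(C)cc5)n4)cc3F)ccnc2cc1OCCCN1CCCC1` has not yet been measured. It differs from compound 2 by methyl in place of hydrogen on an aromatic carbon. Among the compounds with values here, no single-change step between measured compounds is available here. The step of a 1.8-fold lower number from compound 2 to compound 3 (0.26 log units; within the scatter) is expected to be modest and downward, and it may well stay within the scatter. Compound 1 carries the same methyl. In this assay compound 1 gives 580 nM. Compound 3 is therefore estimated at 750 nM, with a range from 300 nM to 1800 nM.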

Compound 3, half-maximal inhibitory concentration: 240 nM
Compound 3: the middle estimate sits 3.1-fold (0.49 log units) above what was measured; measured number outside the range, below it.
By their numbers in this assay, from the lowest: compound 3; then compound 1; then compound 2.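

In this assay, the change from phenyl to 4-methylphenyl with the pyrrolidin-1-yl chain held fixed gives a 5.7-fold lower number from compound 2 to compound 3 (0.75 log units; beyond the scatter), so the methyl on this aromatic carbon, para to a large group, can now be read as a single change, and it lowers the number beyond the scatter. Within the data shown here, the chain end can also be read alone for the first time: with 4-methylphenyl kept, pyrrolidin-1-yl in place of piperidin-1-yl gives a 2.4-fold lower number from compound 1 to compound 3 (0.38 log units; beyond the scatter), again beyond the scatter. Nothing in the data at hand accounts for either step.

The compounds shown leave open whether the methyl step keeps its size with piperidin-1-yl on the chain. They also leave open how an ethyl, a methoxy or a chlorine on the same carbon would compare with methyl.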